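Nitro-to-fluoro swap in the enaminone series, second instance

This account rests on a few compounds, and the source may have more. Where it says the series, first, only, none or still open, it means among the compounds named here.

Measured compounds in a functional assay on HeLa cells (Homo sapiens) for antiproliferative activity, read by sulforhodamine B assay, with a stated time of 48 h; on this read-out lower numbers stand for stronger inhibition and higher numbers for weaker inhibition:
compound 1 `COc1ccc2nc(-c3ccc(N/C=C\C(=O)c4ccc(OC)c(F)c4)c(C)c3)sc2c1` gives 600 nM
compound 2 `COc1ccc(C(=O)/C=C\Nc2ccc(-c3nc4cc(OC)c(OC)c(OC)c4s3)cc2)cc1[N+](=O)[O-]` gives 11400 nM
compound 3 `COc1ccc2nc(-c3ccc(N/C=C\C(=O)c4ccc(OC)c([N+](=O)[O-])c4)c(C)c3)sc2c1` gives 17600 nM

Compounds 1 and 3 share one core and differ at a single place: fluoro in place of nitro on an aromatic carbon. That exchange made the step of a 29-fold lower number from compound 3 to compound 1 (1.47 log units; beyond the scatter), a large move to a lower number in this assay.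

Compound 2 carries a different core; how the core of compound 2 differs from that of compound 3 is not broken down here. In this assay the values of compound 2 and compound 3 lie within the scatter of each other, so no order between them is claimed. Compound 4 `COc1ccc(C(=O)/C=C\Nc2ccc(-c3nc4cc(OC)c(OC)c(OC)c4s3)cc2)cc1F` is not yet measured. It stands to compound 2 as compound 1 stands to compound 3: fluoro in place of nitro on an aromatic carbon. The place lines for the two exchanges agree word for word, so this is the same change made on a second core.

For compound 4 the expectation rests on a single precedent, the step of a 29-fold lower number from compound 3 to compound 1 (1.47 log units; beyond the scatter) on a core that is not the core of compound 2, so the range is kept wide. Compound 4 is expected to move from compound 2 by about a 23-fold lower number from compound 2 to compound 4 (1.36 log units; beyond the scatter) in this assay. Compound 4 is therefore estimated at 500 nM, with a range from 150 nM to 2500 nM.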

Compound 4, half-maximal inhibitory concentration: 7300 nM
For compound 4 the middle estimate is 15-fold (1.16 log units) below the measured one; measured number outside the range, above it.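

In this assay, replacing 4-methoxy-3-nitrophenyl with 3-fluoro-4-methoxyphenyl on the core of compound 2 gives a 1.6-fold lower number from compound 2 to compound 4 (0.19 log units; within the scatter) and so supports no order between these two compounds. The exchange therefore does not carry over in size from one core to the other, and the two steps differ clearly: the same change on two cores in this assay, a 29-fold lower number (1.47 log units; beyond the scatter) from compound 3 to compound 1 and a 1.6-fold lower number (0.19 log units; within the scatter) from compound 2 to compound 4, 19-fold (1.27 log units) apart, beyond the scatter of two such steps

In this series, the step seen on the core of compound 3 cannot be taken as a general value for the exchange, but these two pairs do not show which feature of the cores separates the steps, nor do they give a rule for any third core, since the difference between the two cores is not broken down into single changes here.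

As far as these compounds go, it remains open which part of the core difference sets the size of the step, a question that would need compounds differing from these cores in one place only. From the compounds shown here alone, it also remains open whether an amine or a nitrile at the same place on the aromatic ring would follow the pattern of the core of compound 3 or that of the core of compound 2.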